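The compounds below may be only part of what the source reports. "The series", "measured", "known", "first", "only" and "open" are said of these compounds alone.

Among the compounds with values here, in a functional assay on A549 cells (Homo sapiens) for inhibition, read by sulforhodamine B assay, with a stated time of 48 h, tested at 50 uM (on this read-out lower numbers stand for less inhibition of growth and higher numbers for more inhibition of growth at the one concentration tested), compound 1 `COc1ccc([C@@H]2C/C(=N/OCc3cn(-c4cccc(CO)c4)nn3)c3cc(CC=C(C)C)c(OC)cc3O2)cc1` gives 43% and compound 2 `COc1ccc([C@@H]2C/C(=N/OCc3cn(-c4cc(OC)c(OC)c(OC)c4)nn3)c3cc(CC=C(C)C)c(OC)cc3O2)cc1` gives 28%, so compound 2 holds the lower of the only two numbers available. Compound 3 `COc1ccc([C@@H]2C/C(=N/OCc3cn(-c4ccc(C(N)=O)cc4)nn3)c3cc(CC=C(C)C)c(OC)cc3O2)cc1` keeps the shared core of compound 2 and differs at a single place, with 4-carbamoylphenyl in place of 3,4,5-trimethoxyphenyl on an aromatic nitrogen.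

Within the data shown here, only one measured step bears on this change. It sits at the same place and is modest but beyond the scatter: a number 15 percentage points lower from compound 1 to compound 2 (beyond the scatter). In that step, 3,4,5-trimethoxyphenyl is the group that goes with the lower number, and compound 3 gives this group up. Among the measured compounds shown here, no measured compound carries 4-carbamoylphenyl, however, so this single comparison is a weak guide. A small rise in growth inhibition is therefore expected, an estimated a number 9 percentage points higher from compound 2 to compound 3 (within the scatter). For compound 3 the estimated value is 37%, with an expected range from 22% to 52%.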

Compound 3, percent growth inhibition at one concentration: 100%
Compound 3: the middle estimate sits 63 percentage points below what was measured; the whole stated range lies below it.
By their numbers in this assay, from the lowest: compound 2; then compound 1; then compound 3.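

In this assay, the group on the aromatic nitrogen proves able to shift growth inhibition far more than the first pair suggested: 4-carbamoylphenyl in place of 3,4,5-trimethoxyphenyl gives a large rise (a number 72 percentage points higher from compound 2 to compound 3 (beyond the scatter)), and 4-carbamoylphenyl in place of 3-(hydroxymethyl)phenyl gives another large rise (a number 57 percentage points higher from compound 1 to compound 3 (beyond the scatter)). The earlier comparison between the two other groups was only modest (a number 15 percentage points lower from compound 1 to compound 2 (beyond the scatter)), so this position tolerates more than small changes in the read-out, and among these three compounds the 4-carbamoylphenyl group clearly stands apart, whichever of the two groups it replaces. Nothing available explains why this one group gives so much more inhibition of growth.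

The compounds shown leave open whether the carbamoyl group itself matters or whether a 4-carboxyphenyl or a 4-(aminomethyl)phenyl group on the same nitrogen would give a similar number. With compound 3 at 100% at the one concentration tested, they also leave open how far its inhibition of growth would hold at lower concentrations, a question that a single-concentration read-out cannot settle.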